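Fluoro in place of trifluoromethoxy on the aromatic carbon

This account rests on a few compounds, and the source may have more. Where it says the series, first, only, none or still open, it means among the compounds named here.

Among the compounds with values here, compound 2 `Cc1ccc2nc(-c3ccccc3OC(F)(F)F)[nH]c(=O)c2c1` stands with the lowest of the two numbers measured so far: in a functional assay on HeLa cells (Homo sapiens) for cytotoxicity, read by MTT assay, with a stated time of 2 days (on this read-out lower numbers stand for stronger inhibition and higher numbers for weaker inhibition), compound 2 gives 850 nM, whereas compound 1 `Cc1ccc2nc(-c3ccccc3N(C)C)[nH]c(=O)c2c1` gives 14000 nM. Within the data shown here, the single measured step, a 16-fold lower number from compound 1 to compound 2 (1.22 log units; beyond the scatter), shows that the group on this aromatic carbon moves the read-out strongly. Compound 3 `Cc1ccc2nc(-c3ccccc3F)[nH]c(=O)c2c1` is not yet measured; its change from compound 2 is fluoro in place of trifluoromethoxy on an aromatic carbon. Among the measured compounds shown here, no measured step exchanges trifluoromethoxy for fluoro, so the step from compound 1 to compound 2 bears on it only by showing how sensitive the position is, not in which direction a smaller group moves the number. A modest step toward a higher number is expected, a 2.4-fold higher number from compound 2 to compound 3 (0.37 log units; beyond the scatter), with wide uncertainty. Compound 3 is therefore estimated at 2000 nM, in a range from 500 nM to 8000 nM.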

Compound 3, half-maximal inhibitory concentration: > 50000 nM
Compound 3 ended at the assay's limit; the forecaster's own chance of this, stated with the estimate: 5%; middle value at least 25-fold (1.39 log units) away from the limit.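

In this assay compound 3 stands at a limit of the assay, not at a number: the limit of > 50000 nM in this assay, at which 1 of the 3 values shown sits. The earlier compounds shown here showed that this position is sensitive, and the exchange of trifluoromethoxy (5 heavy atoms) for fluoro (1 heavy atom) now adds a direction for this change, with an at least 58-fold higher number from compound 2 to compound 3 (1.76 log units; beyond the scatter). Fluoro also falls behind dimethylamino, with an at least 3.5-fold higher number from compound 1 to compound 3 (0.55 log units; beyond the scatter), so among these three groups on this aromatic carbon, trifluoromethoxy gives the lowest number and fluoro the highest.

As far as these compounds go, how far the true value of compound 3 lies past the limit stays open. From the compounds shown here alone, whether the low number depends on trifluoromethoxy itself or would also hold for other groups here is equally open, and a methoxy or trifluoromethyl group on this carbon would bear on that.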